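Compound 4: A Shifted Methoxyphenyl Group

This account rests on a few compounds, and the source may have more. Where it says the series, first, only, none or still open, it means among the compounds named here.

In a physicochemical assay for solubility, read by HPLC, in simulated intestinal fluid, with a stated time of 16 h, tested at 125 ug/mL (a lower number here means a less soluble compound, a higher number a more soluble compound), compound 1 (`CNC(=O)c1cc(C(=O)NC2CC2)cn(Cc2ccc(OC)cc2)c1=O`) gives 263 ug/mL and stands within the scatter of compound 3 (`CNC(=O)c1cc(C(=O)NC2CC2)cn(Cc2cccc([C@@H](C)O)c2)c1=O`), which gives 495 ug/mL in the same measurement, and well clear of compound 2 (`CNC(=O)c1cc(C(=O)NC2CC2)cn(Cc2cccc3[nH]ccc23)c1=O`), which gives 17 ug/mL there. Compound 4 (`CNC(=O)c1cc(C(=O)NC2CC2)cn(Cc2cccc(OC)c2)c1=O`) carries 3-methoxyphenyl in place of 4-methoxyphenyl on a saturated chain carbon bound to an aromatic nitrogen. Within the data shown here, two measured steps bear on this: a 1.9-fold higher number from compound 1 to compound 3 (0.27 log units; within the scatter) brings in 3-(1-hydroxyethyl)phenyl, and a 15-fold lower number from compound 1 to compound 2 (1.19 log units; beyond the scatter) brings in 1H-indol-4-yl. Neither keeps the methoxy group, so the guidance is indirect. In this assay the expected change is a 1.1-fold lower number from compound 1 to compound 4 (0.04 log units; within the scatter) and thus none beyond the scatter. For compound 4 the estimated value is 240 ug/mL with an expected range from 100 ug/mL to 500 ug/mL in this measurement.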

Compound 4, solubility: 582 ug/mL
For compound 4 the middle estimate is 2.4-fold (0.38 log units) below the measured one; measured number outside the range, above it.
By their numbers in this assay, from the lowest: compound 2; then compounds 1, 3 and 4 (each within the scatter of the next, the first and the last beyond it).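

In this assay, the same atoms joined differently, 3-methoxyphenyl in place of 4-methoxyphenyl, give a 2.2-fold higher number from compound 1 to compound 4 (0.34 log units; beyond the scatter), so this place responds to the arrangement of the group alone, with its atoms unchanged. Methoxy in place of 1-hydroxyethyl on an aromatic carbon gives a 1.2-fold higher number from compound 3 to compound 4 (0.07 log units; within the scatter), which does not separate the two groups, while 3-methoxyphenyl in place of 1H-indol-4-yl gives a 34-fold higher number from compound 2 to compound 4 (1.53 log units; beyond the scatter). Nothing at hand gives a reason for these steps. Open, from the compounds shown here alone, is how 2-methoxyphenyl would read at this place, and how an amine or a carboxylic acid would read in place of the methoxy group of compound 4.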